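Benzoyl in place of the fluorinated group of compound 3

The compounds below may be only part of what the source reports. "The series", "measured", "known", "first", "only" and "open" are said of these compounds alone.

Compound 1 `O=C(CCCCCCNC(=O)C(O)(O)C(F)(F)F)Nc1ccccc1` gives 9140 nM
Compound 2 `O=C(CCCCCCNC(=O)C(O)(O)C(F)(F)F)Nc1ccc(Br)cc1` gives 3130 nM
Compound 3 `O=C(CCCCCCNC(=O)C(O)(O)C(F)(F)F)Nc1ccc(S(F)(F)(F)(F)F)cc1` gives 9110 nM

In a functional assay on HCT-116 cells (Homo sapiens) for inhibition, read by colorimetric assay, with a stated time of 3 days (a lower number here means a stronger inhibitor, a higher number a weaker inhibitor), compound 3 gives 9110 nM and cannot be told apart from compound 1, whereas compound 2 stands clear of it (a 2.9-fold higher number from compound 2 to compound 3 (0.46 log units; beyond the scatter)). Compound 4 `O=C(CCCCCCNC(=O)C(O)(O)C(F)(F)F)Nc1ccc(C(=O)c2ccccc2)cc1` differs from compound 3 in one place (a group of 8 heavy atoms (7 carbon, 1 oxygen; one six-membered aromatic ring of carbon only) in place of a group of 6 heavy atoms (5 fluorine, 1 sulfur; no ring), on an aromatic carbon). Among the compounds with values here, no measured compound carries benzoyl, so the evidence is indirect. Two steps on that same aromatic carbon bear on the change. The group in compound 3 gave a step within the scatter (a 1.0-fold lower number from compound 1 to compound 3 (0.00 log units; within the scatter)), and the bromine of compound 2 gave only a modest one (a 2.9-fold lower number from compound 1 to compound 2 (0.47 log units; beyond the scatter)). On these two steps, a modest move in this assay is the most that seems likely, and no step beyond the scatter is expected. The estimated step is small and toward a lower number (a 1.5-fold lower number from compound 3 to compound 4 (0.18 log units; within the scatter)). For compound 4 the estimated value is 6000 nM, with an expected range from 2500 nM to 14000 nM.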

Compound 4, half-maximal inhibitory concentration: > 40000 nM
Compound 4 gave a limit, no number (the forecaster's own chance of this, stated with the estimate: 3%); middle value at least 6.6-fold (0.82 log units) away from the limit.
By their numbers in this assay, from the lowest: compound 2; then compounds 3 and 1 (each within the scatter of the next). At a limit, above all of these: compound 4.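

In this assay compound 4 gives a limit and not a number, so every step to it is a bound only: the limit of > 40000 nM in this assay, at which 1 of the 4 values shown sits. This shows that a change on this aromatic carbon can raise the number beyond the scatter as well as lower it, which neither the bromine of compound 2 nor the group of compound 3 showed: the step is an at least 4.3-fold higher number from compound 1 to compound 4 (0.64 log units; beyond the scatter). Set against the other two groups, benzoyl gives an at least 4.3-fold higher number from compound 3 to compound 4 (0.64 log units; beyond the scatter) and an at least 12-fold higher number from compound 2 to compound 4 (1.10 log units; beyond the scatter), the latter a large step.

Whether the carbonyl or the added ring of benzoyl goes with this rise stays open, as neither a phenyl nor an acetyl group on this aromatic carbon stands among the compounds shown. From the compounds shown here alone, how far beyond its limit compound 4 lies also stays open.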